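Removing the propyl group from compound 1: cytotoxicity in HEL cells

A few compounds are considered here, and "the series" means these few. Any claim that something is new, unique, unknown or untested is made for them only; others in the source may bear on it.

Compound 1 has the structure `CCCc1ccc(CCc2cc3cn([C@H]4C[C@H](O)[C@@H](CO)O4)c(=O)nc3o2)cc1`. In an ADME assay on HEL cells (Homo sapiens) for cytotoxicity, with a stated time of 3 days (a lower number here means that less compound is tolerated, a higher number that more compound is tolerated), compound 1 gives > 130000 nM, and this is a limit of the assay rather than a measured number. A second compound, compound 2, with the structure `CCCCCc1ccc(-c2cc3cn([C@H]4C[C@H](O)[C@@H](CO)O4)c(=O)nc3o2)cc1`, was tested in the same way. In this assay compound 2 gives > 50000 nM, which is also a limit of the assay and not a number. So of the two values known here, both are limits, and compound 1 sits at one of them.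

Compound 3, with the structure `O=c1nc2oc(CCc3ccccc3)cc2cn1[C@H]1C[C@H](O)[C@@H](CO)O1`, has not yet been measured. It differs from compound 1 in one place: hydrogen in place of propyl on an aromatic carbon. Within the data shown here, since no measured step between the two known compounds exists, the expectation for this change rests only on where compound 1 stands. The step of a number no higher from compound 1 to compound 3 (the limit leaves the size open) is expected to be none beyond the usual scatter, with the result most likely again reported as a limit. Compound 3 is therefore expected to give about 130000 nM in this assay, within a range of 50000 nM to 300000 nM.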

Compound 3, half-maximal cytotoxic concentration: > 560000 nM
Compound 3: no number, only a limit (the forecaster's own chance of this, stated with the estimate: 80%); at least 4.3-fold (0.63 log units) between middle value and limit.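

In this assay, compound 1 and compound 3 are each reported only as a limit, not as a number, and the step from one to the other cannot be read. The compounds shown leave open whether going from 4-propylphenyl to phenyl changes the tolerated concentration at all, and what concentration of any of them harms the cells.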